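Sulfonamide series: halogenated benzyl replaces dimethoxybenzyl

The source may report more compounds than this note shows. Statements on the series, on what has been measured and on what is new or still open speak of the compounds shown alone.

Three analogues sharing one sulfonamide core have been tested in a toxicity assay on MCF-10A cells (Homo sapiens) for inhibition, read by MTT assay, with a stated time of 72 h; a higher number here means a weaker inhibitor of growth, a lower number a stronger inhibitor of growth. Compound 1 `O=S(=O)(NCCCCNCc1ccc(Br)cc1)c1cc(C(F)(F)F)cc(C(F)(F)F)c1` gives 3200 nM. Compound 2 `COc1ccc(CNCCCNS(=O)(=O)c2cc(C(F)(F)F)cc(C(F)(F)F)c2)cc1OC` gives 5300 nM, the second highest of the three numbers, within the scatter of compound 1 and well separated from compound 3 `O=S(=O)(NCCNCc1cccc2ccccc12)c1cc(C(F)(F)F)cc(C(F)(F)F)c1`, which gives 22000 nM, a higher number beyond the scatter.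

The next compound, compound 4 `O=S(=O)(NCCCNCc1ccc(Cl)c(C(F)(F)F)c1)c1cc(C(F)(F)F)cc(C(F)(F)F)c1`, differs from compound 2 by 4-chloro-3-(trifluoromethyl)phenyl in place of 3,4-dimethoxyphenyl on a saturated chain carbon bound to an amine nitrogen. Going by the values given here, no measured pair isolates this change. Compound 1, which also carries a halogen on its benzyl ring, gives 3200 nM, so the step of a 1.5-fold lower number from compound 2 to compound 4 (0.18 log units; within the scatter) is expected to be small, if anything toward a lower number, and within the scatter. Compound 4 is estimated at 3500 nM, with a range from 1500 nM to 8000 nM.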

Compound 4, concentration for 50% growth inhibition: 7900 nM
Beside the measured number, compound 4's estimate is 2.3-fold (0.35 log units) below it; the measured number falls inside the stated range.
By their numbers in this assay, from the lowest: compounds 1, 2 and 4 (each within the scatter of the next, the first and the last beyond it); then compound 3.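

At the place on a saturated chain carbon bound to an amine nitrogen, the series now has its first single-place comparison: in this assay, 4-chloro-3-(trifluoromethyl)phenyl in place of 3,4-dimethoxyphenyl is a 1.5-fold higher number from compound 2 to compound 4 (0.17 log units; within the scatter). This position therefore accepts either ring without a separation from the scatter in this read-out. No evidence is available that bears on this result.

Still open, on these data alone, is how the chlorine and the trifluoromethyl group each count when taken alone. Also open, as far as these compounds go, is whether a carboxylic acid or a dimethylamino group on this ring would read the same.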